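A few compounds are considered here, and "the series" means these few. Any claim that something is new, unique, unknown or untested is made for them only; others in the source may bear on it.

Working notes on the series, all read in a functional assay on NCI-H1975 cells (Homo sapiens) for cytotoxicity, read by MTT assay, with a stated time of 72 h; a higher number here means a weaker inhibitor, a lower number a stronger inhibitor. Compound 1 (`CN1CCN(c2ccc(Nc3ncc4nc(Nc5ccccc5)n(-c5ccccc5)c4n3)cc2)CC1`) gives 1830 nM, and compound 2 (`CN1CCN(c2ccc(Nc3ncc4nc(Nc5cccc(Cl)c5)n(C5CCCC5)c4n3)cc2)CC1`) gives 390 nM. Compound 2 holds the lower of the two numbers, with a gap to compound 1 beyond the scatter. The two differ in more than one place, so the gap cannot be assigned to a single change. Compound 3 (`CN1CCN(c2ccc(Nc3ncc4nc(Nc5cc(Cl)ccc5Cl)n(C5CCCC5)c4n3)cc2)CC1`) departs from compound 2 in one place: chloro in place of hydrogen on an aromatic carbon. This is chloro in place of hydrogen on an aromatic carbon, ortho to a large group and para to a chloro group, turning 3-chlorophenyl into 2,5-dichlorophenyl. Within the data shown here, the series has no measured single-place step to guide this change, so only a small shift toward a lower number is expected, within the scatter. The estimated change is a 1.3-fold lower number from compound 2 to compound 3 (0.11 log units; within the scatter). Compound 3 is expected at 300 nM, with an estimated range of 90 nM to 1000 nM.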

Compound 3, half-maximal inhibitory concentration: 2540 nM
Compound 3: middle estimate off by 8.5-fold (0.93 log units), on the low side; measured number outside the range, above it.
By their numbers in this assay, from the lowest: compound 2; then compounds 1 and 3 (each within the scatter of the next).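

In this assay, the series now has its first single-place step: chloro in place of hydrogen on the aromatic carbon ortho to a large group and para to a chloro group gives a 6.5-fold higher number from compound 2 to compound 3 (0.81 log units; beyond the scatter). Turning 3-chlorophenyl into 2,5-dichlorophenyl therefore weakens the compound, so this position does not accept chloro without loss in this assay. Nothing at hand gives a reason for this loss.

A fluoro, methyl or methoxy group at this position would show whether the loss is specific to chloro or extends to other groups there. Also open, going by these compounds, is what the existing chloro of compound 2 contributes, which would take a partner carrying plain phenyl and differing from compound 2 in that one place.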